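A few compounds are considered here, and "the series" means these few. Any claim that something is new, unique, unknown or untested is made for them only; others in the source may bear on it.

In an in vivo ADME assay on the whole organism (plasma) for pharmacokinetics, with Rattus norvegicus as the target, at a dose of 50 mg/kg by the oral route (on this read-out higher numbers stand for higher exposure at the dose given and lower numbers for lower exposure), compound 1 (`Cc1cc(C)c(NC(=O)c2sccc2S(=O)(=O)Nc2onc(C)c2Cl)c(C)c1CO`) gives 5110 nM, while compound 2 (`Cc1cc(C)c(NC(=O)c2sccc2S(=O)(=O)Nc2onc(C)c2Cl)c(Cl)c1`) gives 103000 nM, the higher of the two numbers and a gap beyond the usual scatter. Compound 3 (`Cc1cc(C)c(NC(=O)c2sccc2S(=O)(=O)Nc2onc(C)c2Cl)c(C(=O)CS(C)(=O)=O)c1`) carries ((methylsulfonyl)methyl)carbonyl in place of chloro on an aromatic carbon. Among the measured compounds shown here, no measured pair shows this change, so the expectation is loose. The lower number of compound 1, 5110 nM, shows that this core can give much less exposure. The expected change is a moderate drop beyond the scatter, a 3.4-fold lower number from compound 2 to compound 3 (0.54 log units; beyond the scatter). For compound 3 the estimate is 30000 nM, within an expected range of 7000 nM to 100000 nM.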

Compound 3, maximal plasma concentration: 68300 nM
The estimate for compound 3 lay 2.3-fold (0.36 log units) below the measured number; measured number inside the range.
By their numbers in this assay, from the lowest: compound 1; then compounds 3 and 2 (each within the scatter of the next).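

In this assay, the step from chloro to ((methylsulfonyl)methyl)carbonyl on this aromatic carbon gives a 1.5-fold lower number from compound 2 to compound 3 (0.18 log units; within the scatter), so a group of 7 heavy atoms in place of 1 can sit here with no difference beyond the scatter. Adding 3 hydrogen-bond acceptors at this position likewise leaves the two numbers within the scatter of each other. Nothing shown explains this result. As far as these compounds go, it remains open whether an amine or a carboxylic acid on this aromatic carbon would give similar exposure, and whether a longer chain would.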